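The source may report more compounds than this note shows. Statements on the series, on what has been measured and on what is new or still open speak of the compounds shown alone.

The series holds two measured compounds. Compound 1 `NC(=O)c1nccnc1O` in an ADME assay on MDCK cells (Canis lupus familiaris) for cytotoxicity, read by microscopy, with a stated time of 3 days (on this read-out higher numbers stand for lower toxicity in this test and lower numbers for higher toxicity in this test), gives > 250000 nM, which is a limit of the assay rather than a number. Compound 2 `CCCCCCCCCCCCCCC(=O)Oc1ccc(COP(=O)(OCc2ccc(OC(=O)CCCC)cc2)OP(=O)(O)OC[C@H]2O[C@@H](n3cc(F)nc(C(N)=O)c3=O)[C@H](O)[C@@H]2O)cc1` in this assay gives 16000 nM, the only number shown in this set. The value of compound 1 sits at the limit of > 250000 nM in this assay, at which 1 of the 2 values shown sits. Among the measured compounds shown here, no step between two measured compounds is available, so nothing is known here about how a change on the shared core moves the read-out.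

Compound 3 `CCCCCCCCCCCCCCC(=O)Oc1ccc(COP(=O)(OCc2ccc(OC(=O)CCCC)cc2)OP(=O)(O)OC[C@H]2O[C@@H](n3ccnc(C(N)=O)c3=O)[C@H](O)[C@@H]2O)cc1` is not yet measured. It differs from compound 2 by hydrogen in place of fluoro on an aromatic carbon. For the measured compounds named here, with no measured step to rest on, the expected step from compound 2 to compound 3 is no change at the digits printed from compound 2 to compound 3 (within the scatter), which would lie within the scatter of repeated measurements. Compound 3 is therefore estimated at 16000 nM, with a range of 6000 nM to 50000 nM.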

Compound 3, minimum cytotoxic concentration: 16000 nM
For compound 3 middle estimate and measured number coincide at the digits printed; measured number inside the range.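

In this assay, hydrogen in place of fluoro on this aromatic carbon, next to the ring nitrogen and meta to the carbamoyl group, gives no change at the digits printed from compound 2 to compound 3 (within the scatter) as the first step the series can read. For this pair, the read-out therefore does not depend on whether fluoro or hydrogen occupies this position, and the change of one atom here gives no handle on the toxicity seen in this test. Nothing measured here bears on why the step is this small.

On these data alone, whether a different group on the same carbon, such as an amine or a methoxy group, would leave the read-out equally flat stays open. As far as these compounds go, what a shorter chain or a carboxylic acid would do in place of either ester chain also stays open.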